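The compounds below may be only part of what the source reports. "The series", "measured", "known", "first", "only" and "open" are said of these compounds alone.

In an ADME assay on HMEC-1 cells (Homo sapiens) for antiproliferative activity (on this read-out lower numbers stand for stronger inhibition and higher numbers for weaker inhibition), compound 1, `COc1ccc(-c2snnc2-c2cc(OC)c(OC)c(OC)c2)cc1O`, gives 3.9 nM, and compound 2, `COc1ccc(-c2snnc2-c2cc(OC)c(OC)c(OC)c2)cc1OC`, gives 75.8 nM. That is a 19-fold higher number from compound 1 to compound 2 (1.29 log units; beyond the scatter), so a single change on this aromatic ring was enough to shift the read-out well beyond the scatter. Compound 3, `COc1cc(-c2nnsc2-c2ccc([N+](=O)[O-])cc2)cc(OC)c1OC`, sits at a limit of the assay, > 1000 nM, so it has no exact number. Compound 4, `COc1cc(-c2nnsc2-c2ccc(F)cc2)cc(OC)c1OC`, has fluoro in place of nitro on an aromatic carbon, para to a large group: fluoro in place of nitro on an aromatic carbon. Among the measured compounds shown here, no measured step covers this exchange directly. The closest guide is compound 2, whose step a 19-fold higher number from compound 1 to compound 2 (1.29 log units; beyond the scatter) shows that a change on the same ring can be large. A move to a lower number in this assay is therefore expected, though its size is uncertain and compound 4 may also stay at the limit. The estimated step is an at least 3.3-fold lower number from compound 3 to compound 4 (0.52 log units; beyond the scatter). Compound 4 is expected to give about 300 nM, within an estimated range of 60 nM to 1500 nM.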

Compound 4, half-maximal inhibitory concentration: > 1000 nM
Compound 4 ended at the assay's limit (the forecaster's own chance of this, stated with the estimate: 35%); middle value at least 3.3-fold (0.52 log units) away from the limit.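

Compound 3 and compound 4 both sit at a limit of this assay, so no step between them can be read: the limit of > 1000 nM in this assay, at which 2 of the 4 values shown sit.

The compounds shown leave open how far, if at all, fluoro in place of nitro on an aromatic carbon moves the read-out.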